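Compound 3 to compound 4: a methoxybenzyl group returns

The source may hold more compounds than are shown below. What is called first, only, known or untested is meant among the compounds shown, and "the series" means these compounds.

Of the compounds shown here, three have been measured in a functional assay on CHO/Galpha16 cells for antagonist activity at prostaglandin E2 receptor EP4 subtype (Homo sapiens), read by calcium flux, with a stated time of 15 min; on this read-out higher numbers stand for weaker inhibition and lower numbers for stronger inhibition. Compound 1 `COc1cccc(C#Cc2sc3c(c2C(=O)N[C@@H](C)c2ccc(C(=O)O)cc2)CCOC3)c1` gives 12.4 nM, compound 2 `COc1cccc(Cc2sc3c(c2C(=O)N[C@@H](C)c2ccc(C(=O)O)cc2)CCOC3)c1` gives 1.9 nM, and compound 3 `C[C@H](NC(=O)c1c(C#Cc2ccc(=O)[nH]c2)sc2c1CCOC2)c1ccc(C(=O)O)cc1` gives 642 nM. Compound 3 has the highest number of the three and is thus the weakest inhibitor on this read-out: the two steps that lead up to it are a 52-fold higher number from compound 1 to compound 3 (1.71 log units; beyond the scatter) and a 340-fold higher number from compound 2 to compound 3 (2.53 log units; beyond the scatter).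

Compound 4 `COc1ccc(Cc2sc3c(c2C(=O)N[C@@H](C)c2ccc(C(=O)O)cc2)CCOC3)cc1` differs from compound 3 at one place: a group of 9 heavy atoms (8 carbon, 1 oxygen; one six-membered aromatic ring of carbon only) in place of a group of 9 heavy atoms (7 carbon, 1 nitrogen, 1 oxygen; one six-membered aromatic ring with 1 hetero atom), on an aromatic carbon.

Among the measured compounds shown here, the step bearing most directly on this change is the one from compound 2 to compound 3, a 340-fold higher number from compound 2 to compound 3 (2.53 log units; beyond the scatter), which removed a methoxybenzyl group from the same position and gave a large loss. For the measured compounds named here, the step from compound 3 to compound 4 puts a methoxybenzyl group back, though with the methoxy placed as in 4-methoxybenzyl rather than 3-methoxybenzyl, and no measured pair shows how that placement alone affects this assay. The step from compound 1 to compound 2, a 6.5-fold lower number from compound 1 to compound 2 (0.81 log units; beyond the scatter), shows further that a benzyl linker at this position gives a lower number than an ethynyl linker.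

Compound 4 is therefore expected to give a large decrease, a 130-fold lower number from compound 3 to compound 4 (2.11 log units; beyond the scatter), in this assay, to an estimated 5 nM with a range from 1.5 nM to 20 nM.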

Compound 4, half-maximal inhibitory concentration: 2.1 nM
The estimate for compound 4 lay 2.4-fold (0.38 log units) above the measured number, within the range that was stated.
By their numbers in this assay, from the lowest: compounds 2 and 4 (each within the scatter of the next); then compound 1; then compound 3.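

In this assay, the placement of the methoxy on the benzyl ring makes no difference that can be told from the scatter: 4-methoxyphenyl in place of 3-methoxyphenyl gives a 1.1-fold higher number from compound 2 to compound 4 (0.04 log units; within the scatter). The lower number that came with the benzyl linker in a 6.5-fold lower number from compound 1 to compound 2 (0.81 log units; beyond the scatter) also appears with the 4-methoxybenzyl group, at a 5.9-fold lower number from compound 1 to compound 4 (0.77 log units; beyond the scatter), so at this carbon, next to the ring sulfur, that result is not tied to a single methoxy placement among the compounds shown. The large 310-fold lower number from compound 3 to compound 4 (2.49 log units; beyond the scatter) changes the linker and the terminal ring together, so it cannot be divided between them, and no measurement on hand offers a reason for it.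

The compounds shown carry the ring of compound 3 only on the triple-bonded linker, so what that ring does on a saturated chain carbon remains open. Also open, going by these compounds, is whether the benzyl group holds these numbers with no substituent at all, or with a hydroxy group, a chlorine atom or an amine in place of the methoxy.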